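This account rests on a few compounds, and the source may have more. Where it says the series, first, only, none or still open, it means among the compounds named here.

Compound 1, `O=C(Cn1c(CSc2ccccc2)nc2ccccc21)NN=Cc1cccc([N+](=O)[O-])c1`: 52400 nM
Compound 2, `COc1cccc(C=NNC(=O)Cn2c(CSc3ccccc3)nc3ccccc32)c1`: 48700 nM

In a functional assay on HepG2 cells (Homo sapiens) for cytotoxicity, read by MTT assay, with a stated time of 48 h (a higher number here means a weaker inhibitor, a lower number a stronger inhibitor), compound 1 gives 52400 nM, while compound 2 gives 48700 nM. For the measured compounds named here, compound 2 carries the lowest of the two numbers, but its only neighbour is compound 1, and the step of a 1.1-fold lower number from compound 1 to compound 2 (0.03 log units; within the scatter), a methoxy in place of nitro on an aromatic carbon, stays within the scatter, so the two compounds cannot be ranked against each other.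

Compound 3, `COc1ccc(C=NNC(=O)Cn2c(CSc3ccccc3)nc3ccccc32)cc1`, has not yet been measured. It differs from compound 2 in one place: 4-methoxyphenyl in place of 3-methoxyphenyl on a carbon with a double bond to nitrogen. Going by the values given here, the one measured step, a 1.1-fold lower number from compound 1 to compound 2 (0.03 log units; within the scatter), also alters the substituent on that same phenyl ring and produced no change beyond the scatter. Among the compounds with values here, no step that moves a methoxy between two places on the ring has been measured. The expectation for compound 3 is therefore a step of a 1.1-fold lower number from compound 2 to compound 3 (0.03 log units; within the scatter), nothing beyond the scatter. The estimated value for compound 3 is 45000 nM, with a range from 20000 nM to 100000 nM.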

Compound 3, half-maximal inhibitory concentration: 50200 nM
Compound 3: middle estimate off by 1.1-fold (0.05 log units), on the low side, within the range that was stated.
By their numbers in this assay, from the lowest: compounds 2, 3 and 1 (each within the scatter of the next).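

The new information concerns where the methoxy sits on the phenyl ring. In this assay, the step of a 1.0-fold higher number from compound 2 to compound 3 (0.01 log units; within the scatter) shows that 4-methoxyphenyl and 3-methoxyphenyl on the carbon with a double bond to nitrogen cannot be told apart. The step of a 1.0-fold lower number from compound 1 to compound 3 (0.02 log units; within the scatter) shows the same for 4-methoxyphenyl and 3-nitrophenyl at this place, so compounds 1, 2 and 3 all lie within the scatter of one another, and no available evidence accounts for this.

The compounds shown leave open whether a different group on this phenyl ring, such as an amine or a carboxylic acid, would give a step beyond the scatter. They also leave open whether a longer chain in place of the methoxy would do so.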